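Glutarimide series: ring-nitrogen substituent and seizure protection

The source may report more compounds than this note shows. Statements on the series, on what has been measured and on what is new or still open speak of the compounds shown alone.

Measured compounds:
compound 1 `CN1C(=O)C(c2ccccc2)CC(c2ccccc2)C1=O`: 69.1%
compound 2 `Cc1ccc(N2C(=O)C(c3ccccc3)CC(c3ccccc3)C2=O)cc1`: 43.3%
compound 3 `O=C1C(c2ccccc2Cl)CC(c2ccccc2Cl)C(=O)N1Cc1ccccc1`: 58.2%

In a functional assay on the whole organism (strain Swiss albino) for inhibition, with Mus musculus as the target, in the maximal electroshock model, with a stated time of 2 h, at a dose of 25 mg/kg by the intraperitoneal route (a lower number here means less inhibition, a higher number more inhibition at the dose given (going by the name of the read-out)), compound 3 stands second highest of the three; compound 1 lies above it by a margin beyond the scatter, and compound 2 lies below it, also beyond the scatter.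

Compound 4 `Cc1ccc(N2C(=O)C(c3ccccc3Cl)CC(c3ccccc3Cl)C2=O)cc1` has not been measured. It differs from compound 3 as follows: 4-methylphenyl in place of benzyl on an amide-type nitrogen in a ring

Within the data shown here, one measured step bears on this change in part. Putting 4-methylphenyl on the amide-type nitrogen in place of methyl gave a number 25.8 percentage points lower from compound 1 to compound 2 (beyond the scatter). Among the measured compounds shown here, no measured pair shows the exchange of benzyl for 4-methylphenyl, so the size of the step is uncertain, but the entering group is the same as in that step, and a drop is expected.

For compound 4 the expected step is therefore a number 18.2 percentage points lower from compound 3 to compound 4 (beyond the scatter), and compound 4 is estimated at 40% with a range from 22% to 58% in this assay.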

Compound 4, a percentage reported as inhibition, in the whole organism at one dose (the size of the read-out at that dose, not a potency): 58.2%
Beside the measured number, compound 4's estimate is 18.2 percentage points below it; measured number outside the range, above it.
By their numbers in this assay, from the lowest: compound 2; then compounds 3 and 4 (each within the scatter of the next); then compound 1.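

In this assay, no change at the digits printed from compound 3 to compound 4 (within the scatter), so with 2-chlorophenyl groups on the core, benzyl and 4-methylphenyl on the amide-type nitrogen are not told apart. The entering 4-methylphenyl group therefore does not carry a loss of its own: the earlier step, a number 25.8 percentage points lower from compound 1 to compound 2 (beyond the scatter), started from methyl on the core with plain phenyl groups, and the two steps differ in both the leaving group and the aryl groups, so these two influences cannot be separated. Nothing at hand gives a reason for the flat step.

Still open, going by these compounds, is how methyl on this nitrogen behaves with the 2-chlorophenyl groups, and so whether the earlier step carries over to that core. Also open, on these data alone, is what a longer alkyl chain or an aminoethyl chain would give at this position.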